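This account rests on a few compounds, and the source may have more. Where it says the series, first, only, none or still open, it means among the compounds named here.

Measured so far in an ADME assay
- compound 1 `Cc1cc(=O)[nH]c(=O)n1C1O[C@H](C)[C@@H](O)[C@H]1O` gives 9.5
- compound 2 `O=c1cc(CF)n(C2O[C@H](CO)[C@@H](O)[C@H]2O)c(=O)[nH]1` gives 9.8

Compound 1 stands level with compound 2 within the scatter, and two numbers offer little to place it against. Next comes compound 3 `CCc1cc(=O)[nH]c(=O)n1C1O[C@H](C)[C@@H](O)[C@H]1O` which differs from compound 1 by methyl in place of hydrogen on a saturated chain carbon bound to an aromatic carbon and reads as methyl in place of hydrogen on a saturated chain carbon bound to an aromatic carbon, or methyl to ethyl. For the measured compounds named here, no measured pair differs in one place only, so no step is at hand as a guide. In this assay no step beyond the scatter is expected. The estimated move is no change at the digits printed from compound 1 to compound 3 (within the scatter) and stays within the scatter. Compound 3 is expected at 9.5 (estimated range 9.2 to 9.8) until a measurement exists.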

Compound 3, acid dissociation constant: 9.5
Estimate against measurement, compound 3: no gap at the digits printed; the range from low to high includes it.
By their numbers in this assay, from the lowest: compounds 1, 3 and 2 (each within the scatter of the next).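

In this assay this position now has its first direct step: methyl in place of hydrogen on a saturated chain carbon bound to an aromatic carbon gives no change at the digits printed from compound 1 to compound 3 (within the scatter) on the shared core. This is one step for one change, so it sets no trend for the position. No measurement at hand accounts for the reading.

From the compounds shown here alone, whether a longer chain, an amine or a carboxylic acid at this place would give a step beyond the scatter stays open. Also open, going by these compounds, is whether methyl to ethyl would read the same on another core.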